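A few compounds are considered here, and "the series" means these few. Any claim that something is new, unique, unknown or untested is made for them only; others in the source may bear on it.

Measured compounds:
- Compound 1, `Cc1ncnc2c1c(-c1cc3ccccc3o1)cn2[C@@H]1O[C@H](CO)[C@@H](O)[C@H]1O`, gives > 20000 nM in a functional assay on CEM-DNR-bulk cells (Homo sapiens), read by MTT assay, with a stated time of 72 h (on this read-out higher numbers stand for weaker inhibition and lower numbers for stronger inhibition), which is a limit of the assay rather than a number.
- Compound 2, `COc1ncnc2c1c(-c1cc3ccccc3o1)cn2[C@@H]1O[C@H](CO)[C@@H](O)[C@H]1O`, gives 10800 nM in this assay.
- Compound 3, `CNc1ncnc2c1c(-c1cc3ccccc3o1)cn2[C@@H]1O[C@H](CO)[C@@H](O)[C@H]1O`, gives > 20000 nM in this assay, again a limit rather than a number.

Compound 1 therefore stands at the edge of what this assay can report, and it is not alone there: the limit of > 20000 nM in this assay, at which 2 of the 3 values shown sit. Within the data shown here, the only numbered value in this set comes from compound 2, and the step of an at least 1.8-fold lower number from compound 1 to compound 2 (0.26 log units; that floor lies within the scatter) reaches only the floor of what two such values can show. The step that the two limits leave unreadable from compound 1 to compound 3 cannot be read at all, and the step of an at least 1.8-fold higher number from compound 2 to compound 3 (0.26 log units; that floor lies within the scatter) is again a floor. All three of these steps change the small group on the six-membered ring of the shared core.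

Compound 4, `C#Cc1cn([C@@H]2O[C@H](CO)[C@@H](O)[C@H]2O)c2ncnc(C)c12`, differs from compound 1 elsewhere: ethynyl in place of 1-benzofuran-2-yl on an aromatic carbon. Among the measured compounds shown here, no measured step touches this position, so nothing in the data points in either direction, and the starting point is itself a limit. Compound 4 is therefore expected to give 20000 nM, with a range from 5000 nM to 60000 nM. For compound 4 this means an expected step of a number no higher from compound 1 to compound 4 (the limit leaves the size open) that is not beyond the scatter.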

Compound 4, half-maximal inhibitory concentration: 160 nM
Estimate against measurement, compound 4: 130-fold (2.10 log units) above; measured number outside the range, below it.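

The earlier compounds shown here changed only the small group on the six-membered ring of the shared core, and their readable steps were floors within the scatter. Among these compounds, this change, made on the aromatic carbon two ring bonds from the ring nitrogen, gives the first step in the set that is beyond the scatter: in this assay it is an at least 120-fold lower number from compound 1 to compound 4 (2.09 log units; beyond the scatter). As far as these compounds go, the position therefore has a strong bearing on this read-out, with 1-benzofuran-2-yl and its two aromatic rings giving way to ethynyl, which has no ring, although the true size of the step remains unknown, since compound 1 stands at a limit and not at a number: the limit of > 20000 nM in this assay, at which 2 of the 4 values shown sit.

With only these two groups compared at this place, the compounds shown cannot tell whether the triple bond of ethynyl matters or whether another small group, such as a nitrile, a vinyl group or a longer chain such as propynyl, would serve as well. They also leave open whether ethynyl would have the same effect with methoxy or methylamino on the six-membered ring.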